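The compounds below may be only part of what the source reports. "The series", "measured", "known", "first", "only" and "open" are said of these compounds alone.

In a functional assay on MT2 cells (Homo sapiens) for cytotoxicity (a lower number here means that less compound is tolerated, a higher number that more compound is tolerated), compound 1, `Cc1cn([C@H]2C=C[C@@H](CNC(=O)CC3(C)CC(C)(O)CO3)O2)c(=O)[nH]c1=O`, gives only a limit of the assay, > 500000 nM; > 500000 nM (2 entries). Compound 2, `CSCOC1(C)COC(C)(CC(=O)NC[C@@H]2C=C[C@H](n3cc(C)c(=O)[nH]c3=O)O2)C1`, likewise reaches only the limit > 1000000 nM. Compound 3, `CC1=CN([C@H]2C[C@H](O)[C@@H](COC(=O)C[C@@]3(C)C[C@@](C)(O)CO3)O2)C(=O)NC1`, also stands at a limit, > 1000000 nM, so no single number is known for it. The other two entries are limits as well, and most of them sit at the limit of > 1000000 nM in this assay, at which 2 of the 3 values shown sit. Compound 4, `Cc1cn([C@H]2C[C@H](O)[C@@H](COC(=O)C[C@@]3(C)C[C@@](C)(O)CO3)O2)c(=O)[nH]c1=O`, differs from compound 3 in one place: a group of 9 heavy atoms (5 carbon, 2 nitrogen, 2 oxygen; one six-membered aromatic ring with 2 hetero atoms) in place of a group of 8 heavy atoms (5 carbon, 2 nitrogen, 1 oxygen; one six-membered non-aromatic ring with 2 hetero atoms), on a saturated ring carbon. Among the compounds with values here, no step between two measured compounds is available, so the expectation for this change rests on the limits alone. Compound 4 is expected to stay within the scatter, with a step of a number no higher from compound 3 to compound 4 (the limit leaves the size open), because the values shown cluster at the limit of > 1000000 nM in this assay, at which 2 of the 3 values shown sit. In this assay compound 4 is therefore estimated at 1000000 nM, between 300000 nM and 3000000 nM.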

Compound 4, half-maximal cytotoxic concentration: > 1000000 nM
Compound 4 ended at the assay's limit; the forecaster's own chance of this, stated with the estimate: 90%; the middle value sits exactly at the limit.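

Within the data shown here, compound 3 and compound 4 both end at a limit of the assay, so no step between them can be read. The compounds shown leave open at what concentration any of them turns cytotoxic in this assay.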